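Two Methyls in Place of a Fluorine on the Sulfonamide Aryl

The source may report more compounds than this note shows. Statements on the series, on what has been measured and on what is new or still open speak of the compounds shown alone.

Measured so far:
compound 1 `Cc1cc(C(O)(C(F)(F)F)C(F)(F)F)ccc1N(CC(C)C)S(=O)(=O)c1ccc2c(c1)C(O)CC(C1CCOCC1)O2` – 4.37
compound 2 `CCc1ccc(NS(=O)(=O)c2ccc3c(c2)C(O)CC(C2CCOCC2)O3)cc1` – 2.59
compound 3 `CC(C)CN(c1cccc(F)c1)S(=O)(=O)c1ccc2c(c1)C(O)CC(C1CCOCC1)O2` – 3.39

All three compounds share one core and were characterised in a physicochemical assay for lipophilicity, at pH 7.4; a higher number here means a more lipophilic compound, a lower number a more polar compound. Compound 3 stands second highest of the three numbers: compound 2 lies a good deal lower, compound 1 a good deal higher, and both gaps are beyond the usual scatter of the method.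

Compound 4 `Cc1ccc(N(CC(C)C)S(=O)(=O)c2ccc3c(c2)C(O)CC(C2CCOCC2)O3)c(C)c1` has not yet been measured. It differs from compound 3 in a single spot: 2,4-dimethylphenyl in place of 3-fluorophenyl on a sulfonamide nitrogen. The group that leaves and the group that enters carry neither hydrogen-bond donors nor acceptors and neither bears a charge; the group that enters is counted as one heavy atom larger.

Within the data shown here, no measured pair here isolates this exchange, so the expected size of the step rests on the change itself. Compound 4 is expected to come out above compound 3 by a step of a number 0.71 log units higher from compound 3 to compound 4 (beyond the scatter), which is beyond the scatter. The estimate for compound 4 in this assay is 4.1, with a range from 3.7 to 4.5.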

Compound 4, distribution coefficient: 4.19
Compound 4: the middle estimate sits 0.09 log units below what was measured, within the range that was stated.
By their numbers in this assay, from the lowest: compound 2; then compound 3; then compounds 4 and 1 (each within the scatter of the next).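

In this assay, 2,4-dimethylphenyl in place of 3-fluorophenyl on a sulfonamide nitrogen gives the only step shown at this position (a number 0.80 log units higher from compound 3 to compound 4 (beyond the scatter)), a modest one. Methyl in place of 2,2,2-trifluoro-1-hydroxy-1-(trifluoromethyl)ethyl on an aromatic carbon gives a second step (a number 0.18 log units lower from compound 1 to compound 4 (within the scatter)), so this read-out does not separate that pair, even though the two compounds differ by this large group. Nothing at hand bears on why either step has the size it has.

On these data alone, the step from compound 3 to compound 4 removes the fluorine and adds both methyls at once, so how much each of these changes contributes remains open. Also open, as far as these compounds go, is where an amine or a carboxylic acid on the aryl group would fall in this assay.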